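This account rests on a few compounds, and the source may have more. Where it says the series, first, only, none or still open, it means among the compounds named here.

In an assay on isolated protein for inhibition of Polyunsaturated fatty acid 5-lipoxygenase (Homo sapiens) (on this read-out higher numbers stand for weaker inhibition and lower numbers for stronger inhibition), compound 1 `Cc1ccc(N2CCCC(=O)N2)cc1` gives 277000 nM, and compound 2 `CCc1ccc(N2CCCC(=O)N2)cc1` gives 125000 nM. Among the compounds with values here, the single measured step, a 2.2-fold lower number from compound 1 to compound 2 (0.35 log units; beyond the scatter), shows that a methyl in place of hydrogen on a saturated chain carbon bound to an aromatic carbon brings a modest change. Compound 3 `O=C1CCCN(c2cccc(Cl)c2)N1` stands apart: in this assay compound 3 gives 2500 nM, the lowest of the three numbers, far below both compound 2 and compound 1. Compound 4 `CC(C)(C)C(=O)c1cccc(N2CCCC(=O)N2)c1` differs from compound 3 by (tert-butyl)carbonyl in place of chloro on an aromatic carbon. Within the data shown here, no measured step replaces a chloro with a (tert-butyl)carbonyl, so the only guide is the small alkyl-growth step from compound 1 to compound 2, which sits on a different position and is not a true precedent. The expected step from compound 3 to compound 4 is therefore uncertain in direction and estimated as a 2.0-fold higher number from compound 3 to compound 4 (0.30 log units; within the scatter). For compound 4 the value in this assay is estimated at 5000 nM, with a range from 1000 nM to 25000 nM.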

Compound 4, half-maximal inhibitory concentration: 15000 nM
Estimate against measurement, compound 4: 3.0-fold (0.48 log units) below; low and high end bracket the measured number.
By their numbers in this assay, from the lowest: compound 3; then compound 4; then compound 2; then compound 1.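

In this assay, within the data shown here, the step on this aromatic carbon, meta to a group of 7 heavy atoms, is the first at this position: (tert-butyl)carbonyl in place of chloro gives a 6.0-fold higher number from compound 3 to compound 4 (0.78 log units; beyond the scatter). The change swaps 1 heavy atom for 6 and adds 1 hydrogen-bond acceptor, yet compound 4 still gives 15000 nM, so this position tolerates the larger group with a modest rise in the number, but this single step cannot separate the effect of the carbonyl from that of the tert-butyl. Nothing shown gives a measured reason for the step.

The compounds shown leave open how a plain tert-butyl, with no carbonyl, would compare at this position. They also leave open whether an amine or a carboxylic acid there would stand nearer compound 3 or compound 4.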